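This account rests on a few compounds, and the source may have more. Where it says the series, first, only, none or still open, it means among the compounds named here.

Going by the values given here, compound 2 `CC1=CC[C@H](C(C)(C)NC(=S)N/N=C/c2ccc(Cl)cc2)CC1` gives 8600 nM in a functional assay on OVCAR-3 cells (Homo sapiens) for inhibition, read by sulforhodamine B assay, with a stated time of 48 h (on this read-out lower numbers stand for stronger inhibition of growth and higher numbers for weaker inhibition of growth), the only number in the set. Compound 1 `CC1=CC[C@H](C(C)(C)NC(=S)N/N=C/c2ccc(F)cc2)CC1` sits at the limit of > 100000 nM in this assay, at which 1 of the 2 values shown sits. In this assay compound 1 gives > 100000 nM, a limit and not a number. Among the compounds with values here, the sole measured step is an at least 11-fold lower number from compound 1 to compound 2 (1.06 log units; beyond the scatter). Compound 3 `CC1=CC[C@H](C(C)(C)NC(=S)N/N=C/c2ccc[nH]2)CC1` differs from compound 2 by 1H-pyrrol-2-yl in place of 4-chlorophenyl on a carbon with a double bond to nitrogen. Within the data shown here, no measured step covers such a ring swap, so the expectation rests on compound 2 alone and carries a wide range. A step of a 4.7-fold higher number from compound 2 to compound 3 (0.67 log units; beyond the scatter) is expected. For compound 3 the estimate is 40000 nM, between 10000 nM and 150000 nM.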

Compound 3, concentration for 50% growth inhibition: 33500 nM
Beside the measured number, compound 3's estimate is 1.2-fold (0.08 log units) above it; the measured number falls inside the stated range.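

On the carbon with a double bond to nitrogen, a phenyl ring is not required for a measurable number in this assay: 1H-pyrrol-2-yl, with its hydrogen-bond donor, still gives one, though weaker than 4-chlorophenyl (a 3.9-fold higher number from compound 2 to compound 3 (0.59 log units; beyond the scatter)) and stronger than 4-fluorophenyl (an at least 2.9-fold lower number from compound 1 to compound 3 (0.47 log units; beyond the scatter)). Compound 1 stands at a limit and not a number, so this last step has only a lower bound: the limit of > 100000 nM in this assay, at which 1 of the 3 values shown sits.

Open, on these data alone, is whether the ring's hydrogen-bond donor matters, which a 1-methylpyrrol-2-yl group would test. Also open, as far as these compounds go, is how a 4-bromophenyl or pyridin-2-yl group would rank here.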